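This account rests on a few compounds, and the source may have more. Where it says the series, first, only, none or still open, it means among the compounds named here.

Compound 1 `O=C(NO)c1ccc(CN(Cc2ccncc2)S(=O)(=O)c2cc(F)c(F)c(F)c2F)cc1` and compound 2 `O=C(NO)c1ccc(CN(Cc2ccc(F)cc2)S(=O)(=O)c2cc(F)c(F)c(F)c2F)cc1` share one core and differ only at the group on the saturated chain carbon bound to the sulfonamide nitrogen. Among the measured compounds shown here, in an assay on isolated protein for inhibition of protein deacetylase HDAC6 (Homo sapiens), read by mobility shift assay (on this read-out lower numbers stand for stronger inhibition and higher numbers for weaker inhibition), compound 1 gives 11 nM and compound 2 gives 21 nM; the step of a 1.9-fold higher number from compound 1 to compound 2 (0.28 log units; within the scatter) means compound 2 sits within the scatter of compound 1, the only other number in hand. Compound 3 `O=C(NO)c1ccc(CN(Cc2ccccc2F)S(=O)(=O)c2cc(F)c(F)c(F)c2F)cc1` carries the change (2-fluorophenyl in place of 4-fluorophenyl on a saturated chain carbon bound to a sulfonamide nitrogen). For the measured compounds named here, no measured step moves a fluorine around this ring; the one comparison shows the aryl group tolerant of change, so the step of a 1.2-fold higher number from compound 2 to compound 3 (0.08 log units; within the scatter) is expected to stay within the scatter. Compound 3 is estimated at 25 nM, range 10 nM to 60 nM.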

Compound 3, half-maximal inhibitory concentration: 10 nM
Compound 3: middle estimate off by 2.5-fold (0.40 log units), on the high side, and the stated range covers the measured number.
By their numbers in this assay, from the lowest: compounds 3, 1 and 2 (each within the scatter of the next, the first and the last beyond it).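

In this assay, among the compounds shown here, the place of the fluorine on this ring does count: a 2.1-fold lower number from compound 2 to compound 3 (0.32 log units; beyond the scatter) is the first step at this position to lie beyond the scatter, though only modestly. With a 1.1-fold lower number from compound 1 to compound 3 (0.04 log units; within the scatter) the 2-fluorophenyl and pyridin-4-yl groups cannot be told apart, so the aryl group at this position accepts either ring. No measured evidence bears on why the fluorine's place matters.

Open, as far as these compounds go, is how 3-fluorophenyl or 2-chlorophenyl would read at this position. Also open, from the compounds shown here alone, is whether a saturated cyclohexyl group or a 2-aminophenyl group would hold the number.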